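Trimming a methoxy group on the carbonyl-side aryl ring

The source may hold more compounds than are shown below. What is called first, only, known or untested is meant among the compounds shown, and "the series" means these compounds.

Measured so far:
- compound 1, `COc1cc(-c2cc(/C=C/C(=O)c3ccc(N)cc3)[nH]n2)cc(OC)c1OC`: -78%
- compound 2, `COc1cc(-c2cc(/C=C/C(=O)c3ccc(Cl)c(Cl)c3)[nH]n2)cc(OC)c1OC`: 16%
- compound 3, `COc1ccc(C(=O)/C=C/c2cc(-c3cc(OC)c(OC)c(OC)c3)n[nH]2)cc1OC`: -93%

All three share one core and differ only in the aryl group attached to the carbonyl carbon. In a functional assay on LOX IMVI cells (Homo sapiens) for cytotoxicity, read by sulforhodamine B assay, with a stated time of 48 h, tested at 10 uM (a lower number here means a stronger effect, a higher number a weaker effect of the compound at the concentration tested), compound 3 gives the lowest number of the three. The step of a number 15 percentage points lower from compound 1 to compound 3 (beyond the scatter) is modest, whereas the step of a number 109 percentage points lower from compound 2 to compound 3 (beyond the scatter) is large, and the step of a number 94 percentage points higher from compound 1 to compound 2 (beyond the scatter) is large as well.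

Compound 4, `COc1ccc(C(=O)/C=C/c2cc(-c3cc(OC)c(OC)c(OC)c3)n[nH]2)cc1`, has not yet been measured. It differs from compound 3 in one place: hydrogen in place of methoxy on an aromatic carbon.

Within the data shown here, none of the measured steps makes this same change; all three swap the whole aryl group, and the two large ones replace one pair of substituents with a quite different pair. Among the measured compounds shown here, the change here is smaller, removing only one group from a ring that otherwise stays the same, so a step of a size well below the large ones is expected in this assay, more likely towards a weaker effect than a stronger one, and possibly none beyond the scatter. The expected step is a number 23 percentage points higher from compound 3 to compound 4 (beyond the scatter). For compound 4 the estimate is -70%, within a range from -100% to -20%.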

Compound 4, a percentage reported as activity, at one concentration (the size of the read-out at that concentration, not a potency): -92%
The estimate for compound 4 lay 22 percentage points above the measured number; the range from low to high includes it.
By their numbers in this assay, from the lowest: compounds 3 and 4 (each within the scatter of the next); then compound 1; then compound 2.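

In this assay, going from 3,4-dimethoxyphenyl to 4-methoxyphenyl leaves the two compounds indistinguishable (a number 1 percentage points higher from compound 3 to compound 4 (within the scatter)), so at this concentration the methoxy group that leaves is not needed for the effect, something the earlier whole-aryl swaps could not show. The 4-methoxyphenyl group also stands apart from the other two aryl groups much as the 3,4-dimethoxyphenyl group does: the distance from the dichlorophenyl compound is large (a number 108 percentage points lower from compound 2 to compound 4 (beyond the scatter)), and the step with methoxy in place of amino is modest (a number 14 percentage points lower from compound 1 to compound 4 (beyond the scatter)). Nothing available explains why the methoxy group can leave without a detectable difference.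

On these data alone, it stays open whether the remaining methoxy group matters, which a plain phenyl ring, or a hydroxy or ethoxy group at that place, would test. This read-out also gives the size of the effect at a single concentration rather than a potency, so compound 3 and compound 4 might still separate at lower concentrations.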